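The compounds below may be only part of what the source reports. "The series", "measured", "known", "first", "only" and "open" are said of these compounds alone.

Compound 1 `O=C(O)c1cccc(C2=C(c3cc(Cl)ccc3OCc3ccccc3)CCC2)c1` was examined in an assay on isolated protein for inhibition of prostaglandin E2 receptor EP3 subtype (Homo sapiens); on this read-out higher numbers stand for weaker inhibition and lower numbers for stronger inhibition. In this assay compound 1 gives < 3170 nM, which is a limit of the assay and not a number. Compound 2 `O=C(O)c1cccc(C2=C(c3cc(Br)ccc3OCc3ccccc3)CCC2)c1` carries bromo in place of chloro; in this assay compound 2 gives < 3170 nM, again a limit rather than a number. The step that the two limits leave unreadable from compound 1 to compound 2 is therefore of unreadable size. Compound 3 `CS(=O)(=O)c1ccc(OCc2ccc(F)cc2)c(C2=C(c3cccc(C(=O)O)c3)CCC2)c1` also stands only at a limit: in this assay compound 3 gives < 3170 nM. All three values shown sit at the same point, (the limit of < 3170 nM in this assay, at which 3 of the 3 values shown sit). Compound 4 `CS(=O)(=O)c1ccc(OCc2ccccc2)c(C2=C(c3cccc(C(=O)O)c3)CCC2)c1` differs from compound 3 by hydrogen in place of fluoro on an aromatic carbon. No measured step bears directly on this change, and the only step shown is unreadable, so no shift beyond the scatter is expected. Compound 4 is therefore expected to give about 1500 nM, within 300 nM to 5000 nM. This corresponds to an expected step that the limit leaves unreadable from compound 3 to compound 4.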

Compound 4, half-maximal inhibitory concentration: < 3170 nM
Compound 4: no number, only a limit; the forecaster's own chance of this, stated with the estimate: 70%; the middle value does not contradict the limit.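

In this assay compound 4 gives < 3170 nM, which is a limit and not a number. Among these compounds, no step among compound 1, compound 2, compound 3 and compound 4 can therefore be read: the limit of < 3170 nM in this assay, at which 4 of the 4 values shown sit. What the compounds shown leave open is how far apart they truly lie, and so what any of these single changes does.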